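From 3-fluorophenyl to 4-fluorophenyl in the series

The source may report more compounds than this note shows. Statements on the series, on what has been measured and on what is new or still open speak of the compounds shown alone.

Within the data shown here, in a functional assay on the whole organism for inhibition, with Mythimna separata as the target, with a stated time of 5 days (a lower number here means that less compound is needed, a higher number that more compound is needed for the effect), compound 1 (`CC(C)(C)n1ncc(OCc2nnc(-c3ccccc3Cl)o2)c(Cl)c1=O`) gives 61200 nM, while compound 2 (`CC(C)(C)n1ncc(OCc2nnc(-c3cccc(F)c3)o2)c(Cl)c1=O`) gives 7100 nM, the lowest of the two numbers so far. Compound 3 (`CC(C)(C)n1ncc(OCc2nnc(-c3ccc(F)cc3)o2)c(Cl)c1=O`) keeps the core of compound 2 and carries 4-fluorophenyl in place of 3-fluorophenyl on an aromatic carbon. Among the measured compounds shown here, no measured pair isolates this change. For the measured compounds named here, the only step that bears on it is an 8.6-fold lower number from compound 1 to compound 2 (0.94 log units; beyond the scatter), which lies beyond the scatter and is modest in size. That step replaces 2-chlorophenyl with 3-fluorophenyl, so the halogen and the group name change together, and it gives only indirect guidance here. It shows that a change on this aromatic group can move the number in this assay, but it does not give a direction for the present change. No step beyond the scatter is therefore expected, although the range must stay wide. The expected change is a 1.1-fold higher number from compound 2 to compound 3 (0.05 log units; within the scatter). The estimate for compound 3 is 8000 nM, with an expected range of 2200 nM to 28000 nM.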

Compound 3, half-maximal effective concentration: 5200 nM
Compound 3: the middle estimate sits 1.5-fold (0.19 log units) above what was measured, and the stated range covers the measured number.
By their numbers in this assay, from the lowest: compounds 3 and 2 (each within the scatter of the next); then compound 1.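

In this assay, 4-fluorophenyl in place of 3-fluorophenyl gives a 1.4-fold lower number from compound 2 to compound 3 (0.14 log units; within the scatter), so this direct comparison of the two fluorophenyl groups on the same aromatic carbon shows no difference that can be separated from the scatter. Replacing 2-chlorophenyl with 4-fluorophenyl gives a 12-fold lower number from compound 1 to compound 3 (1.07 log units; beyond the scatter), a large step beyond the scatter, and together with the earlier step this places compound 2 and compound 3 together, apart from compound 1, whichever of the two fluorophenyl groups is present. No independent measurement is available to explain either the closeness of compound 2 and compound 3 or the gap to compound 1.

The compounds shown leave open whether that gap follows the identity of the halogen or its place on the phenyl ring, since compound 1 differs from the other two in both, and 2-fluorophenyl or 4-chlorophenyl would separate the two. Also open, going by these compounds, is how the number in this assay would respond to unsubstituted phenyl, or to a phenyl carrying a methoxy group or a carboxylic acid instead of a halogen.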